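This account rests on a few compounds, and the source may have more. Where it says the series, first, only, none or still open, it means among the compounds named here.

Measured compounds in an ADME assay on the whole organism with Oryza sativa as the target, tested at 1 uM; on this read-out higher numbers stand for a weaker effect at the one concentration tested and lower numbers for a stronger effect:
compound 1 `C[C@@H](NC(=O)Nc1cccc(C(F)(F)F)c1)c1ccccc1`: compound 1 gives 72%
compound 2 `C[C@H](NC(=O)Nc1cccc(C(F)(F)F)c1)c1ccccc1`: compound 2 gives 93%
compound 3 `C[C@@H](NC(=O)Nc1cc(C(F)(F)F)cc(C(F)(F)F)c1)c1ccccc1`: compound 3 gives 93%

Compound 3 stands level with compound 2 and apart from compound 1; together these two give the highest numbers of the three. The move to compound 4 `C[C@H](NC(=O)Nc1cc(C(F)(F)F)cc(C(F)(F)F)c1)c1ccccc1` is the two compounds have the same atoms and bonds and differ only in configuration as drawn: 1 of 1 stereo elements differ; a stereocentre at a saturated chain carbon is drawn R in compound 3 and S in compound 4. For the measured compounds named here, one measured step bears on it directly: a number 21 percentage points higher from compound 1 to compound 2 (beyond the scatter), a change resting on (the fact that compounds 1 and 2 differ only in the configuration as drawn). The other step, a number 21 percentage points higher from compound 1 to compound 3 (beyond the scatter), brought in the second trifluoromethyl that compound 3 and compound 4 share. Compound 3 already gives 93%, close to the top of the scale, so the same configurational change can add only a little. The step of a number 2 percentage points higher from compound 3 to compound 4 (within the scatter) is expected to be small. Compound 4 is therefore estimated at 95%, within 82% to 100%.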

Compound 4, a percentage reported as activity, at one concentration (the size of the read-out at that concentration, not a potency): 95%
Compound 4: middle estimate and measured number agree at the digits printed; measured number inside the range.
By their numbers in this assay, from the lowest: compound 1; then compounds 2, 3 and 4 (each within the scatter of the next).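

With two trifluoromethyl groups on the shared core, the configuration at the saturated chain carbon no longer gives a step beyond the scatter: a number 2 percentage points higher from compound 3 to compound 4 (within the scatter), whereas with one such group a number 21 percentage points higher from compound 1 to compound 2 (beyond the scatter). Trifluoromethyl in place of hydrogen on an aromatic carbon also proves dependent on the configuration as drawn, as a number 2 percentage points higher from compound 2 to compound 4 (within the scatter) in the S pair. Its step therefore does not carry over unchanged between the two configurations: the same change on two cores in this assay, a number 21 percentage points higher (beyond the scatter) from compound 1 to compound 3 and a number 2 percentage points higher (within the scatter) from compound 2 to compound 4, 19 percentage points apart, beyond the scatter of two such steps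

On these data alone, whether a nitrile or a chlorine in place of the added trifluoromethyl would also remove the gap between the two configurations remains open.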